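The source may hold more compounds than are shown below. What is called first, only, known or untested is meant among the compounds shown, and "the series" means these compounds.

Among the measured compounds shown here, in a functional assay on DU-145 cells (Homo sapiens) for inhibition, read by MTT assay, with a stated time of 48 h (a lower number here means a stronger inhibitor, a higher number a weaker inhibitor), compound 1 `CCn1c(/C=C2\SC(=O)N(CC(=O)N3CCCC3)C2=O)nc2ccccc21` gives 45100 nM, the only numeric value so far. Compound 2 `CC(C)n1c(/C=C2\SC(=O)N(CC(=O)N3CCOCC3)C2=O)nc2ccccc21` reads > 50000 nM in this assay, which is a limit of the assay and not a number. Compound 3 `CC(C)n1c(/C=C2\SC(=O)N(CC(=O)N3CCCC3)C2=O)nc2ccccc21` has pyrrolidin-1-yl in place of morpholin-4-yl on a carbonyl carbon. For the measured compounds named here, no measured step is available for this change, so only a small gain in inhibition is expected in this assay, bringing it close to compound 1 at 45100 nM. The expected step is an at least 1.2-fold lower number from compound 2 to compound 3 (0.09 log units; that floor lies within the scatter). For compound 3 the estimate is 40000 nM, with an expected range of 20000 nM to 60000 nM.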

Compound 3, half-maximal inhibitory concentration: > 50000 nM
Compound 3 ended at the assay's limit; the forecaster's own chance of this, stated with the estimate: 40%; at least 1.2-fold (0.09 log units) between middle value and limit.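

In this assay the change from morpholin-4-yl to pyrrolidin-1-yl on a carbonyl carbon cannot be read, because compound 2 and compound 3 both sit at a limit of the assay and neither gives a number: the limit of > 50000 nM in this assay, at which 2 of the 3 values shown sit.

Methyl in place of hydrogen on a saturated chain carbon bound to an aromatic nitrogen and a saturated chain carbon gives an at least 1.1-fold higher number from compound 1 to compound 3 (0.04 log units; that floor lies within the scatter), so this change is not shown to weaken inhibition. Among the compounds shown here, compound 1 remains the only compound with a numeric value, 45100 nM.

As far as these compounds go, whether morpholin-4-yl and pyrrolidin-1-yl differ at all stays open. So does the effect of piperazin-1-yl on the same carbonyl carbon.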